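Triazole series: cytotoxicity on A-431 cells, all at the limit

A few compounds are considered here, and "the series" means these few. Any claim that something is new, unique, unknown or untested is made for them only; others in the source may bear on it.

Compound 1 `O=[N+]([O-])c1cc(-c2nnc(SCc3ccc(Cl)cc3)n2Cc2ccccc2)cc([N+](=O)[O-])c1`: in an ADME assay on A-431 cells (Homo sapiens) for cytotoxicity, with a stated time of 48 h (on this read-out lower numbers stand for stronger inhibition and higher numbers for weaker inhibition), compound 1 gives > 30000 nM, a limit of the assay.
Compound 2 `O=[N+]([O-])c1cc(-c2nnc(SCc3ccc(Cl)c(Cl)c3)n2Cc2ccccc2)cc([N+](=O)[O-])c1`: in this assay compound 2 gives > 30000 nM, again a limit.
Compound 3 `O=[N+]([O-])c1cc(-c2nnc(SCc3ccc(Cl)cc3)n2Cc2ccccc2)cc(C(F)(F)F)c1`: in this assay compound 3 gives > 30000 nM, also a limit.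

The three measured compounds share one core and differ at two places. From compound 1 to compound 2 the change is chloro in place of hydrogen on an aromatic carbon; the step is a step that the two limits leave unreadable from compound 1 to compound 2. From compound 1 to compound 3 the cores differ by trifluoromethyl in place of nitro on an aromatic carbon; the step is a step that the two limits leave unreadable from compound 1 to compound 3. Neither step can be read because of the limit of > 30000 nM in this assay, at which 3 of the 3 values shown sit.

Compound 4 `O=[N+]([O-])c1cc(-c2nnc(SCc3ccc(Cl)c(Cl)c3)n2Cc2ccccc2)cc(C(F)(F)F)c1` is not yet measured. It differs from compound 3 by chloro in place of hydrogen on an aromatic carbon, the same kind of change as from compound 1 to compound 2, and the two changes sit at places described in the same words, so the change is taken as the same.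

Among the compounds with values here, since the only measured instance of this change runs from one limit to another, the step from compound 3 to compound 4 is expected to be a number no higher from compound 3 to compound 4 (the limit leaves the size open), an expectation resting on a step that the two limits leave unreadable from compound 1 to compound 2 and on (the limit of > 30000 nM in this assay, at which 3 of the 3 values shown sit). Compound 4 is therefore estimated at 30000 nM in this assay. The expected range for compound 4 runs from 15000 nM to 60000 nM, and most likely only a limit will again be reported.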

Compound 4, half-maximal inhibitory concentration: > 30000 nM
Compound 4 gave a limit, no number (the forecaster's own chance of this, stated with the estimate: 85%); the middle value lies on the limit itself.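

In this assay no new step can be read from compound 3 to compound 4 or from compound 2 to compound 4, because all these values are limits of the assay: the limit of > 30000 nM in this assay, at which 4 of the 4 values shown sit.

The compounds shown leave open whether any of the four has a measurable cytotoxic potency on these cells, and whether either chloro in place of hydrogen or trifluoromethyl in place of nitro changes it.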